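Moving a methyl group around a phenyl ring

The compounds below may be only part of what the source reports. "The series", "measured", "known", "first", "only" and "open" are said of these compounds alone.

The compounds measured so far, all in an assay on cells (Oocyte) for negative allosteric modulation of glutamate receptor ionotropic, NMDA 2D (Rattus norvegicus), read by two-electrode voltage clamp; a higher number here means a weaker inhibitor, a lower number a stronger inhibitor:

compound 1 `O=C(O)CCC(=O)N1N=C(c2c(-c3ccccc3)c3cc(Cl)ccc3[nH]c2=O)CC1c1ccc(Br)cc1` gives 3100 nM
compound 2 `O=C(O)CCC(=O)N1N=C(c2c(-c3ccc(Cl)cc3)c3ccccc3[nH]c2=O)CC1c1ccccc1` gives 11000 nM
compound 3 `Cc1ccc(-c2c(C3=NN(C(=O)CCC(=O)O)C(c4ccc(Cl)cc4)C3)c(=O)[nH]c3ccccc23)cc1` gives 1400 nM

All three share one core, and they differ in the two aromatic rings attached to it and in the substituents carried by the core itself. Compound 3 has the lowest number of the three in this assay, and therefore the strongest inhibition; the gap to compound 1 and the larger gap to compound 2 both lie beyond the scatter of repeated measurements, so compound 3 is the strongest inhibitor of the measured set.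

Compound 4 `Cc1cccc(-c2c(C3=NN(C(=O)CCC(=O)O)C(c4ccc(Cl)cc4)C3)c(=O)[nH]c3ccccc23)c1` has not yet been measured. It differs from compound 3 by a single change: 3-methylphenyl in place of 4-methylphenyl on an aromatic carbon. The same atoms are present, simply joined in a different arrangement on that ring.

Within the data shown here, no pair of measured compounds shows this kind of rearrangement on its own, so there is nothing within the set to say how far such a shift moves the number. The expectation is a step from compound 3 of a 1.4-fold higher number from compound 3 to compound 4 (0.15 log units; within the scatter), small and uncertain in direction, within or close to the scatter. Compound 4 is therefore estimated at 2000 nM, with a likely range from 700 nM to 6000 nM.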

Compound 4, half-maximal inhibitory concentration: 1900 nM
For compound 4 the middle estimate is 1.1-fold (0.02 log units) above the measured one; low and high end bracket the measured number.
By their numbers in this assay, from the lowest: compounds 3, 4 and 1 (each within the scatter of the next, the first and the last beyond it); then compound 2.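

In this assay, the change from 4-methylphenyl to 3-methylphenyl gives a 1.4-fold higher number from compound 3 to compound 4 (0.13 log units; within the scatter). Among these compounds, this is the first pair in the set that differs in only one place, and it gives a first direct reading of this ring: for this pair, the two placements of the methyl group cannot be told apart, so neither compound can be ranked above the other. Nothing available explains why this rearrangement leaves the two numbers so close.

As far as these compounds go, it remains open what the methyl group itself contributes, since compound 1 carries a plain phenyl ring at this position but also differs from compound 3 and compound 4 elsewhere, so it cannot answer that question. From the compounds shown here alone, it is also open whether a different group on this ring, such as an ethyl group, a methoxy group or an amine, would keep the number within the scatter of compound 3 or move it clearly, as this single pair says nothing about groups other than methyl.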